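Trading Benzyloxycarbonyl for Methoxycarbonyl in Compound 3

This account rests on a few compounds, and the source may have more. Where it says the series, first, only, none or still open, it means among the compounds named here.

Among the measured compounds shown here, in a physicochemical assay for lipophilicity, at pH 7.4 (a higher number here means a more lipophilic compound, a lower number a more polar compound), compound 3 `Cc1cc(NC(=O)OCc2ccccc2)nn1Cc1cc(Cl)ccc1OCc1ccccc1` gives 3.1, the only exact number. Compound 1 `Cc1cc(C(=O)NC(C)C)nn1Cc1cc(Cl)ccc1OCc1ccccc1` reaches only a limit of the assay, > 3.7. Compound 2 `Cc1cc(NC(=O)c2ccccc2)nn1Cc1cc(Cl)ccc1OCc1ccccc1` also gives only a limit, > 3.7. Compound 4 `COC(=O)Nc1cc(C)n(Cc2cc(Cl)ccc2OCc2ccccc2)n1` differs from compound 3 by hydrogen in place of phenyl on a saturated chain carbon bound to an oxygen next to a carbonyl group, so benzyloxycarbonyl becomes methoxycarbonyl. For the measured compounds named here, no measured step removes a phenyl at this place. The closest is benzyloxy in place of phenyl on a carbonyl carbon, a number at least 0.60 log units lower from compound 2 to compound 3 (beyond the scatter), while the wider change gives a number at least 0.60 log units lower from compound 1 to compound 3 (beyond the scatter). With a whole phenyl leaving and only hydrogen entering, a clear fall in this assay is expected, a number 0.90 log units lower from compound 3 to compound 4 (beyond the scatter). For compound 4 the estimated value is 2.2, within a range of 1.6 to 2.8.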

Compound 4, distribution coefficient: > 3.7
Compound 4: a limit, no number; the forecaster's own chance of this, stated with the estimate: 5%; middle value at least 1.50 log units from the limit.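

In this assay, replacing benzyloxycarbonyl with methoxycarbonyl gives a number at least 0.60 log units higher from compound 3 to compound 4 (beyond the scatter), so losing the phenyl at this place does not lower the number. Compound 4 gives > 3.7, a limit and not a number. The earlier steps shown here left open whether the lower number of compound 3 belonged to its carbamoyl-free amino-carbonyl-oxygen link as such, but compound 4 keeps that link with methoxy in place of benzyloxy.

The steps from compound 1 and compound 2 to compound 4 cannot be read, because the readings stop at a limit: the limit of > 3.7 in this assay, at which 3 of the 4 values shown sit. From the compounds shown here alone, whether an ethyl group, a longer chain or an amine at this place would give a number remains open.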